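Changing one amide side chain: compound 3 to compound 4

A few compounds are considered here, and "the series" means these few. Any claim that something is new, unique, unknown or untested is made for them only; others in the source may bear on it.

Measured in a functional assay on MCF7 cells (Homo sapiens) for antiproliferative activity, read by MTT assay, with a stated time of 24 h (a lower number here means a stronger inhibitor, a higher number a weaker inhibitor), as follows
- compound 1 `CCn1c(C(=O)NCC(=O)OC)ccc1C(CC)(CC)c1ccc(OCS(=O)(=O)c2ccccc2)c(C)c1` gives > 50000 nM as a limit of the assay
- compound 2 `CCN(CC)CCNC(=O)c1ccc(C(CC)(CC)c2ccc(OCS(=O)(=O)c3ccccc3)c(C)c2)n1CC` gives 4680 nM as a number
- compound 3 `CCn1c(C(=O)N[C@H](CO)C(C)C)ccc1C(CC)(CC)c1ccc(OCS(=O)(=O)c2ccccc2)c(C)c1` gives 25500 nM as a number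

Among the compounds with values here, only two of these values are exact numbers, and they lie clearly apart, with a 5.4-fold higher number from compound 2 to compound 3 (0.74 log units; beyond the scatter) in this series. Compound 3 therefore holds the higher exact number, which marks it as the weaker inhibitor of that pair.

Compound 4 `CCn1c(C(=O)N[C@@H](CO)CCO)ccc1C(CC)(CC)c1ccc(OCS(=O)(=O)c2ccccc2)c(C)c1` differs from compound 3 in one place 3-hydroxy-1-(hydroxymethyl)propyl in place of 1-(hydroxymethyl)-2-methylpropyl on an amide-type nitrogen with 3-hydroxy-1-(hydroxymethyl)propyl in place of 1-(hydroxymethyl)-2-methylpropyl on an amide-type nitrogen.

All measured steps fall on this same nitrogen. The largest, an at least 10-fold lower number from compound 1 to compound 2 (1.02 log units; beyond the scatter) for the change to (diethylamino)methyl, involves a group that compound 4 lacks, so it offers little guidance. Closer is an at least 1.9-fold lower number from compound 1 to compound 3 (0.29 log units; that floor lies within the scatter) as a step between side chains without that group. No step beyond the scatter is therefore expected in this assay for this change. The expected change is a 1.3-fold higher number from compound 3 to compound 4 (0.10 log units; within the scatter) by this estimate. Compound 4 is estimated at 32000 nM with an expected range from 14000 nM to 50000 nM in this test.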

Compound 4, half-maximal inhibitory concentration: 27400 nM
Compound 4: middle estimate off by 1.2-fold (0.07 log units), on the high side, and the stated range covers the measured number.
By their numbers in this assay, from the lowest: compound 2; then compounds 3 and 4 (each within the scatter of the next). At a limit, above all of these: compound 1.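

On this amide-type nitrogen, 3-hydroxy-1-(hydroxymethyl)propyl, with 2 hydrogen-bond donors, can take the place of 1-(hydroxymethyl)-2-methylpropyl, with 1, and the result is a 1.1-fold higher number from compound 3 to compound 4 (0.03 log units; within the scatter) in this assay with no readable change. The 2-(diethylamino)ethyl chain still stands apart from this second hydroxyl-bearing chain, with a 5.9-fold higher number from compound 2 to compound 4 (0.77 log units; beyond the scatter) as the step, just as it stood apart from the chain of compound 3. The step of an at least 1.8-fold lower number from compound 1 to compound 4 (0.26 log units; that floor lies within the scatter) rests on a limit and cannot be read as a size: the limit of > 50000 nM in this assay, at which 1 of the 4 values shown sits.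

As far as these compounds go, whether the lower number of compound 2 belongs to the diethylamino group in particular stays open, and a dimethylamino group or a piperidine on the same chain would test that. From the compounds shown here alone, a carboxylic acid in place of the methyl ester of compound 1 is also open.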